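Aryl swap on the shared core: compound 1 to compound 3

A few compounds are considered here, and "the series" means these few. Any claim that something is new, unique, unknown or untested is made for them only; others in the source may bear on it.

Working notes on the series. Compound 1 `O=C1CC(c2nc(-c3ccc(F)cc3)no2)CN1c1ccc(Cl)c(Cl)c1` is the reference point. Among the compounds with values here, in an in vitro functional assay on HEK293-A cells for positive allosteric modulation of metabotropic glutamate receptor 5 (Homo sapiens), read by FLIPR and calcium flux (on this read-out higher numbers stand for an effect only at larger amounts of compound and lower numbers for an effect already at smaller amounts), compound 1 gives 2300 nM, the lowest of the two numbers measured so far. Compound 2 `COc1cccc(-c2noc(C3CC(=O)N(c4ccc(Cl)cc4)C3)n2)c1` differs from compound 1 in two places at once. In this assay compound 2 gives 4800 nM; that gap lies beyond the usual scatter, so compound 1 carries the lower number of the pair. Within the data shown here, no pair of measured compounds differs in a single place, so no isolated change has yet been quantified.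

Compound 3 `Cc1cccc(-c2noc(C3CC(=O)N(c4ccc(Cl)c(Cl)c4)C3)n2)c1` is not yet measured. Relative to compound 1 the change is 3-methylphenyl in place of 4-fluorophenyl on an aromatic carbon; the rest of compound 1 is kept. Compound 2 shows that a different aryl group together with a second change raised the number, but that cannot be separated into a single contribution. The step expected for compound 3 is a 1.4-fold higher number from compound 1 to compound 3 (0.14 log units; within the scatter), a modest rise that may stay within the scatter. Compound 3 is estimated at 3200 nM in this assay, with a range of 1300 nM to 8000 nM.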

Compound 3, half-maximal effective concentration: 390 nM
For compound 3 the middle estimate is 8.2-fold (0.91 log units) above the measured one; the whole stated range lies above it.
By their numbers in this assay, from the lowest: compound 3; then compound 1; then compound 2.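

The position on the five-membered aromatic ring, between two ring nitrogen atoms, now has its first isolated measurement: in this assay, 3-methylphenyl in place of 4-fluorophenyl gives a 5.9-fold lower number from compound 1 to compound 3 (0.77 log units; beyond the scatter). The number at this position therefore responds to the aryl group even though the group that enters and the group that leaves have the same count of heavy atoms, the same six-membered aromatic ring of carbon only, and no hydrogen-bond donors or acceptors. No measurement bears on the reason for this step.

This single step changes both the kind of group on the phenyl ring and where that group sits, so the lower number cannot be assigned to the methyl group, to the loss of fluorine, or to the new location alone. Also open, from the compounds shown here alone, is how this position responds to an unsubstituted phenyl ring, to an amine or a carboxylic acid on the aryl ring, or to a longer chain such as ethyl in place of the methyl group.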